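The compounds below may be only part of what the source reports. "The series", "measured", "known", "first", "only" and "open" are said of these compounds alone.

Three stilbenes carrying a methoxy group on one ring and a hydroxy or amino group on the other were tested in a functional assay on MCF7 cells (Homo sapiens) for inhibition, read by MTT assay, with a stated time of 2 days; a lower number here means a stronger inhibitor, a higher number a weaker inhibitor. Compound 1, `COc1ccc(/C=C/c2ccccc2O)cc1`, gives 17 ug/mL in this assay. Compound 2, `COc1ccccc1/C=C/c1cccc(O)c1`, has the same atoms as compound 1 joined differently; the difference between the two cores is not broken down here. In this assay compound 2 gives 24.3 ug/mL, and the two values lie within the usual scatter of each other. Compound 3, `COc1ccc(/C=C/c2ccccc2N)cc1`, differs from compound 1 by amino in place of hydroxy on an aromatic carbon. In this assay compound 3 gives 0.4 ug/mL. This single change produced a 43-fold lower number from compound 1 to compound 3 (1.63 log units; beyond the scatter), by far the largest movement among the three measured compounds.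

Compound 4, `COc1ccccc1/C=C/c1cccc(N)c1`, has not yet been measured in this assay. It differs from compound 2 by amino in place of hydroxy on an aromatic carbon. Among the measured compounds shown here, this is the same kind of change as the one from compound 1 to compound 3, with the difference that in compound 3 the amino group stands ortho to a large group, whereas in compound 4 it stands meta to a large group. Because the change from compound 1 to compound 3 gave a 43-fold lower number from compound 1 to compound 3 (1.63 log units; beyond the scatter), a step of comparable direction is expected for compound 4, though its size is uncertain since the place of the change is not the same. Compound 4 is estimated at 0.8 ug/mL, between 0.25 ug/mL and 4 ug/mL, which would be an expected step of a 30-fold lower number from compound 2 to compound 4 (1.48 log units; beyond the scatter).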

Compound 4, half-maximal inhibitory concentration: 38.7 ug/mL
Estimate against measurement, compound 4: 48-fold (1.68 log units) below; measured number outside the range, above it.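

In this assay, amino in place of hydroxy on an aromatic carbon, here meta to a large group, gives a 1.6-fold higher number from compound 2 to compound 4 (0.20 log units; within the scatter). The large step seen on the core of compound 1 therefore does not carry over to the core of compound 2, and the size of this change cannot be read from one core to the other in this series: the same change on two cores in this assay, a 43-fold lower number (1.63 log units; beyond the scatter) from compound 1 to compound 3 and a 1.6-fold higher number (0.20 log units; within the scatter) from compound 2 to compound 4, 68-fold (1.83 log units) apart, beyond the scatter of two such steps What this does not show is which difference between the cores matters: they hold the same atoms joined differently, so the placing of the methoxy group and the placing of the changed group cannot be separated, and two pairs of compounds give no rule for any further core.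

On these data alone, it stays open which of these placings goes with the low number of compound 3, at 0.4 ug/mL, and whether the amino group is needed in the form it has there. As far as these compounds go, it also stays open whether a dimethylamino group, an acetamide or a fluorine at the same place would follow the step to compound 3 or the step to compound 4.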